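This account rests on a few compounds, and the source may have more. Where it says the series, first, only, none or still open, it means among the compounds named here.

Compound 1 `CC(=O)SCCC(CCCCC(=O)O)SC(C)=O`: 9.89%
Compound 2 `O=C(CCCCC1CCSS1)Nc1cccc2ccccc12`: 4.15%

In a functional assay on NCI-H460 cells (Homo sapiens) for inhibition, read by MTT assay, with a stated time of 24 h, tested at 1 ug/mL (on this read-out higher numbers stand for more inhibition of growth at the one concentration tested and lower numbers for less inhibition of growth), compound 1 gives 9.89% and compound 2 gives 4.15%, two values that lie within the usual scatter of each other. Compound 3 `CC(=O)SCCC(CCCCC(=O)Nc1ccc(Cl)cc1)SC(C)=O` keeps the core of compound 1 and carries (4-chlorophenyl)amino in place of hydroxy on a carbonyl carbon. Within the data shown here, no measured pair shows a change of this kind, so only a modest rise in this assay is expected, and it may not clear the scatter. The estimated change is a number 8.1 percentage points higher from compound 1 to compound 3 (within the scatter). For compound 3 the expected value is 18%, within an estimated range of 4% to 42%.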

Compound 3, percent growth inhibition at one concentration: 15.4%
Estimate against measurement, compound 3: 2.6 percentage points above, within the range that was stated.
By their numbers in this assay, from the lowest: compounds 2, 1 and 3 (each within the scatter of the next, the first and the last beyond it).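

In this assay, the first step read at this position, (4-chlorophenyl)amino in place of hydroxy on a carbonyl carbon, gives a number 5.5 percentage points higher from compound 1 to compound 3 (within the scatter). The carboxylic acid hydroxy of compound 1 can thus give way to this larger group, with its six-membered aromatic ring, without the read-out leaving the scatter. Nothing measured here bears on the reason for this result.

From the compounds shown here alone, what the chlorine contributes stays open, as does whether a plain phenylamino or a benzylamine on the same carbonyl carbon would give a step beyond the scatter in this assay.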